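The source may report more compounds than this note shows. Statements on the series, on what has been measured and on what is new or still open speak of the compounds shown alone.

Of the compounds shown here, two have been read so far. In a functional assay on MDA-MB-231 cells (Homo sapiens) for inhibition, read by MTT assay, with a stated time of 72 h (a higher number here means a weaker inhibitor, a lower number a stronger inhibitor), compound 1 `CC(C)(C)n1cc2c(n1)C(=O)CC1(CCN(C(=O)c3cc(-c4ccc(F)cc4)nc4ccccc34)CC1)O2` gives > 10000 nM, which is a limit of the assay and not a number. For the measured compounds named here, compound 2 `COc1ccc(-c2cc(C(=O)N3CCC4(CC3)CC(=O)c3nn(C(C)(C)C)cc3O4)c3ccccc3n2)cc1OC` gives 7130 nM, the sole actual number available. The measured step of an at least 1.4-fold lower number from compound 1 to compound 2 (0.14 log units; that floor lies within the scatter) brings 3,4-dimethoxyphenyl in place of 4-fluorophenyl on an aromatic carbon. Its size is known only as a floor, and that floor lies within the scatter.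

Next in line is compound 3 `CC(C)(C)n1cc2c(n1)C(=O)CC1(CCN(C(=O)c3cc(-c4ccc(N)cc4)nc4ccccc34)CC1)O2`, with the change 4-aminophenyl in place of 3,4-dimethoxyphenyl on an aromatic carbon: 4-aminophenyl in place of 3,4-dimethoxyphenyl on the same aromatic carbon, next to the ring nitrogen. Going by the values given here, the one guide to a change at this carbon is the step to compound 2, an at least 1.4-fold lower number from compound 1 to compound 2 (0.14 log units; that floor lies within the scatter), so no step beyond the scatter is expected in this assay, in either direction. Uncertainty stays wide, and another limit reading is possible, given (the limit of > 10000 nM in this assay, at which 1 of the 2 values shown sits). The expected step is a 1.0-fold lower number from compound 2 to compound 3 (0.01 log units; within the scatter). For compound 3 the estimated value is 7000 nM, with an expected range from 2000 nM to 20000 nM.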

Compound 3, half-maximal inhibitory concentration: 4960 nM
The estimate for compound 3 lay 1.4-fold (0.15 log units) above the measured number; low and high end bracket the measured number.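

In this assay, 4-aminophenyl in place of 3,4-dimethoxyphenyl gives a 1.4-fold lower number from compound 2 to compound 3 (0.16 log units; within the scatter), so this aromatic carbon takes a group with a hydrogen-bond donor and without the two methoxy groups, and no step beyond the scatter results. Amino in place of fluoro gives an at least 2.0-fold lower number from compound 1 to compound 3 (0.30 log units; that floor lies within the scatter), which adds a second comparison at this carbon, and with it all three aryl groups shown here are linked by steps that do not leave the scatter. Compound 1 stands at a limit of the assay and not at a number, so the size of this second step remains a floor: the limit of > 10000 nM in this assay, at which 1 of the 3 values shown sits.

On these data alone, whether any replacement at this aromatic carbon can move the number beyond the scatter remains open. A carboxylic acid or a dimethylamino group on the same phenyl ring, or an unsubstituted phenyl, would test how far the reading depends on this substituent at all.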